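The compounds below may be only part of what the source reports. "The series", "measured", "known", "first", "only" and "open" are said of these compounds alone.

Working notes on the series. In a functional assay on HepG2 cells (Homo sapiens) for cytotoxicity, read by MTT assay, with a stated time of 72 h (on this read-out higher numbers stand for weaker inhibition and lower numbers for stronger inhibition), compound 1 `CNC(=O)c1cc(Oc2ccc(C(=O)/C=C/c3ccc(Cl)c(Cl)c3)cc2)ccn1` gives 11400 nM as a measured number. Compound 2 `CNC(=O)c1cc(Oc2ccc(C(=O)/C=C/c3ccc(Br)cc3)cc2)ccn1` has only a limit in this assay with > 50000 nM as its entry, so it has no exact place on the scale. The next change leads to compound 3 `CNC(=O)c1cc(Oc2ccc(C(=O)/C=C/c3ccc(F)cc3Cl)cc2)ccn1` and reads 2-chloro-4-fluorophenyl in place of 4-bromophenyl on a double-bonded chain carbon bound to a double-bonded chain carbon in words: 2-chloro-4-fluorophenyl in place of 4-bromophenyl on a double-bonded chain carbon bound to a double-bonded chain carbon. Among the measured compounds shown here, one measured step bears on this, at the same place: an at least 4.3-fold higher number from compound 1 to compound 2 (0.64 log units; beyond the scatter) which is modest but beyond the scatter, and is itself bounded by a limit. Compound 3 keeps chlorine on the phenyl as compound 1 does, so a modest move towards a lower number is expected in this assay rather than no change. That single step is thin support, and a second reading at the limit stays possible. The estimated change is an at least 2.2-fold lower number from compound 2 to compound 3 (0.35 log units; beyond the scatter) on this reasoning. The estimate for compound 3 is 22000 nM with an expected range of 9000 nM to 50000 nM as a working figure.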

Compound 3, half-maximal inhibitory concentration: 7320 nM
Compound 3: the middle estimate sits 3.0-fold (0.48 log units) above what was measured; measured number below the stated range.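

At this place, on a double-bonded chain carbon bound to a double-bonded chain carbon, 2-chloro-4-fluorophenyl in place of 4-bromophenyl gives an at least 6.8-fold lower number from compound 2 to compound 3 (0.83 log units; beyond the scatter) in this assay, and this brings the series back from a limit to a measured number. The two phenyl groups that carry chlorine do not separate, as 2-chloro-4-fluorophenyl in place of 3,4-dichlorophenyl gives only a 1.6-fold lower number from compound 1 to compound 3 (0.19 log units; within the scatter), so among these three compounds a measured number is not tied to a single chlorine arrangement, and no compound shown goes against this. Compound 2 stands only as a limit, so each of its steps is a bound and not a measured size: the limit of > 50000 nM in this assay, at which 1 of the 3 values shown sits.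

The compounds shown do not separate the effect of removing bromine from that of adding chlorine or fluorine, and they do not show what the fluorine in 2-chloro-4-fluorophenyl contributes alone. On these data alone, how a phenyl group carrying an amine, a carboxylic acid or a methoxy group would read at this place in this assay also stays open, as does whether any of these steps carries over to a different core.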